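Methoxy Added to a Compound Without Measurable Inhibition

A few compounds are considered here, and "the series" means these few. Any claim that something is new, unique, unknown or untested is made for them only; others in the source may bear on it.

The study concerns two measured compounds and one still to be tested. Compound 1, `CCCCCC/C=C/c1cc(C)oc(=O)c1`, was examined in a functional assay on A2780 cells (Homo sapiens) for inhibition; on this read-out higher numbers stand for weaker inhibition and lower numbers for stronger inhibition. In this assay compound 1 reaches only a limit of the assay, > 50000 nM, and no number. Compound 2, `Cc1cc(-c2ccccc2)cc(=O)o1`, likewise gives in this assay only a limit, > 50000 nM. Where compound 2 stands is therefore a boundary rather than a point, as the limit of > 50000 nM in this assay, at which 2 of the 2 values shown sit, shows. Compound 3, `COc1ccc(-c2cc(C)oc(=O)c2)cc1`, differs from compound 2 by methoxy in place of hydrogen on an aromatic carbon. Among the compounds with values here, no step between measured compounds is available, so the size of the change can only be anticipated. The expected step is a step that the limit leaves unreadable from compound 2 to compound 3, that is none beyond the scatter. Compound 3 is estimated in this assay at 60000 nM, with a range from 20000 nM to 200000 nM, and the likeliest outcome is that compound 3 is again reported only as a limit.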

Compound 3, half-maximal inhibitory concentration: > 50000 nM
Compound 3 was reported as a limit (the forecaster's own chance of this, stated with the estimate: 85%); the middle value lies beyond the limit too.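

No new step can be read: compound 2 and compound 3 each give only a limit of the assay in this assay, not a number. The compounds shown leave open whether methoxy in place of hydrogen on an aromatic carbon alters inhibition at all.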